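Adding a Third Methoxy Group: Little Change Expected

This account rests on a few compounds, and the source may have more. Where it says the series, first, only, none or still open, it means among the compounds named here.

Of the compounds shown here, two have so far been tested in a functional assay on A549 cells (Homo sapiens) for cytotoxicity, read by MTT assay, with a stated time of 72 h; a lower number here means a stronger inhibitor, a higher number a weaker inhibitor. Compound 1, with the structure `COc1cc(OC)c(/C=C/C(=O)c2ccccc2F)c(OC)c1`, carries three methoxy groups. In this assay compound 1 gives > 100000 nM, which is a limit of the assay rather than a measured number. Compound 2, with the structure `COc1ccc(C(=O)/C=C/c2ccc(OC)cc2OC)c(F)c1`, carries two methoxy groups instead. In this assay compound 2 likewise gives > 100000 nM, again a limit and not a number. So compound 2 stands at the edge of what the assay can report, and the one other value shown sits at that same edge: the limit of > 100000 nM in this assay, at which 2 of the 2 values shown sit.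

Compound 3, with the structure `COc1ccc(C(=O)/C=C/c2c(OC)cc(OC)cc2OC)c(F)c1`, is not yet measured. It differs from compound 2 in one place, methoxy in place of hydrogen on an aromatic carbon. Among the compounds with values here, with no measured step to lean on, and both known compounds at the limit, no change beyond the usual scatter is expected, so the step is estimated at a step that the limit leaves unreadable from compound 2 to compound 3. Compound 3 is therefore expected to give about 150000 nM in this assay, within a range from 30000 nM to 800000 nM, most likely reported once more only as a limit.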

Compound 3, half-maximal inhibitory concentration: > 100000 nM
Compound 3 was reported as a limit; the forecaster's own chance of this, stated with the estimate: 75%; the middle value does not contradict the limit.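

In this assay compound 3 gives > 100000 nM, which is a limit and not a number. The steps from compound 1 and from compound 2 to compound 3 cannot be read, because all values sit at the same edge: the limit of > 100000 nM in this assay, at which 3 of the 3 values shown sit.

The compounds shown leave open how strongly any of them acts on these cells, and whether the added methoxy changes that at all.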